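Methoxy for Methyl: Expected Cytotoxicity of Compound 4

The source may hold more compounds than are shown below. What is called first, only, known or untested is meant among the compounds shown, and "the series" means these compounds.

Three compounds have been measured in a functional assay on EC9706 cells (Homo sapiens) for cytotoxicity, read by MTT assay, with a stated time of 72 h; on this read-out lower numbers stand for stronger inhibition and higher numbers for weaker inhibition:

Compound 1 `NC(=O)N1CCN(C(=S)SCc2cn(Cc3ccc(F)cc3)nn2)CC1` gives 62700 nM.
Compound 2 `NC(=O)N1CCN(C(=S)SCc2cn(Cc3ccc(Cl)cc3)nn2)CC1` reaches only a limit, > 128000 nM.
Compound 3 `Cc1ccc(Cn2cc(CSC(=S)N3CCN(C(N)=O)CC3)nn2)cc1` likewise reaches only a limit, > 128000 nM.

Compound 3 therefore stands at the limit of > 128000 nM in this assay, at which 2 of the 3 values shown sit; no number is known for it, only that limit. Among the measured steps, an at least 2.0-fold higher number from compound 1 to compound 2 (0.30 log units; that floor lies within the scatter) and an at least 2.0-fold higher number from compound 1 to compound 3 (0.30 log units; that floor lies within the scatter) both run toward weaker inhibition, while a step that the two limits leave unreadable from compound 2 to compound 3 cannot be sized.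

Compound 4 `COc1ccc(Cn2cc(CSC(=S)N3CCN(C(N)=O)CC3)nn2)cc1` differs from compound 3 by methoxy in place of methyl on an aromatic carbon. Among the compounds with values here, none of the measured steps involves a methoxy group, so no step bears directly on this change; the nearest evidence is that compound 3 itself sits at the limit of > 128000 nM in this assay, at which 2 of the 3 values shown sit. With only a limit as the starting point, the step from compound 3 to compound 4 is expected to be a number no higher from compound 3 to compound 4 (the limit leaves the size open), that is, none readable beyond the scatter. Compound 4 is accordingly estimated at 128000 nM in this assay, within a range of 40000 nM to 300000 nM, with a substantial chance that only a limit is reported again.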

Compound 4, half-maximal inhibitory concentration: > 128000 nM
Compound 4 was reported as a limit (the forecaster's own chance of this, stated with the estimate: 65%); the middle value lies on the limit itself.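

With 4-methoxybenzyl in place of 4-methylbenzyl, compound 4 is reported only as a limit, > 128000 nM, in this assay. Methoxy, which brings an oxygen and a hydrogen-bond acceptor to the position para to a large group, thus joins chloro and methyl at the limit, leaving fluoro in compound 1 as the only group here with a number: the limit of > 128000 nM in this assay, at which 3 of the 4 values shown sit. Within the data shown here, the one readable step is an at least 2.0-fold higher number from compound 1 to compound 4 (0.30 log units; that floor lies within the scatter), while the steps to compound 4 from compound 2 and compound 3 cannot be read.

Going by these compounds, the order of compound 2, compound 3 and compound 4 remains open, since none of them has a number. Also open, on these data alone, is whether an amine or a carboxylic acid at this position would give a number in this assay.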